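Trimming an ethyl to methyl in a urea series

The source may hold more compounds than are shown below. What is called first, only, known or untested is meant among the compounds shown, and "the series" means these compounds.

Three related compounds have been measured so far. Compound 1 `CCOc1ccc(NC(=O)Nc2cccc(CNc3nccnc3Cl)c2)cc1` carries a 4-ethoxyphenyl on an amide-type nitrogen, and in a functional assay on T-24 cells (Homo sapiens) for antiproliferative activity, read by MTT assay, with a stated time of 48 h (a higher number here means a weaker inhibitor, a lower number a stronger inhibitor), compound 1 gives 9080 nM. Compound 2 `COc1ccc(NC(=O)Nc2cccc(CNc3nccnc3Cl)c2)cc1` differs from it by hydrogen in place of methyl on a saturated chain carbon bound to an oxygen on an aromatic ring; in this assay compound 2 gives 9820 nM. That change made a step of a 1.1-fold higher number from compound 1 to compound 2 (0.03 log units; within the scatter). Compound 3 `CCc1ccccc1NC(=O)Nc1cccc(CNc2nccnc2Cl)c1` rests on a different core, differing from compound 1 by 2-ethylphenyl in place of 4-ethoxyphenyl on an amide-type nitrogen. In this assay compound 3 gives 8720 nM; the step from compound 1 to compound 3 is a 1.0-fold lower number from compound 1 to compound 3 (0.02 log units; within the scatter), and the step from compound 2 to compound 3 is a 1.1-fold lower number from compound 2 to compound 3 (0.05 log units; within the scatter). All three numbers thus sit close together.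

The unmeasured compound 4 `Cc1ccccc1NC(=O)Nc1cccc(CNc2nccnc2Cl)c1` differs from compound 3 by hydrogen in place of methyl on a saturated chain carbon bound to an aromatic carbon. Among the measured compounds shown here, this is the same kind of change as the one from compound 1 to compound 2, but not the same: there the saturated chain carbon that loses its methyl is bound to an oxygen on an aromatic ring, here it is bound to an aromatic carbon. The step expected from this change is a 1.1-fold higher number from compound 3 to compound 4 (0.04 log units; within the scatter), on the ground that the same kind of change earlier gave a 1.1-fold higher number from compound 1 to compound 2 (0.03 log units; within the scatter). For the measured compounds named here, only one such earlier example exists, so the expectation is loose. On that basis compound 4 is expected to give about 9500 nM in this assay, most likely between 4000 nM and 22000 nM.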

Compound 4, half-maximal inhibitory concentration: 13600 nM
Compound 4: the middle estimate sits 1.4-fold (0.16 log units) below what was measured, within the range that was stated.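

Trimming the ethyl to methyl gives a 1.6-fold higher number from compound 3 to compound 4 (0.19 log units; within the scatter) in this assay, and compound 4 also stays within the scatter of the other two compounds, with a 1.4-fold higher number from compound 2 to compound 4 (0.14 log units; within the scatter) and a 1.5-fold higher number from compound 1 to compound 4 (0.18 log units; within the scatter). Set side by side, the two cases of losing a methyl do not differ measurably: the same change on two cores in this assay, a 1.1-fold higher number (0.03 log units; within the scatter) from compound 1 to compound 2 and a 1.6-fold higher number (0.19 log units; within the scatter) from compound 3 to compound 4, 1.4-fold (0.16 log units) apart, within the scatter of two such steps. Among the compounds shown here, on these two cores the change therefore behaves alike, in that neither step leaves the scatter, but this rests on only two pairs, and it shows neither that the change has a real effect in this assay nor that it would behave the same way on a further core.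

The compounds shown leave open whether a larger change at this place, such as a carboxylic acid, an amine or a longer chain like butyl in place of the ethyl of compound 3, would move the number beyond the scatter. They also leave open whether the close agreement among these four compounds would hold in any other assay, since every number here comes from the same cells and the same read-out.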